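Swapping acetamido for methylsulfonyl on the benzylamide

This account rests on a few compounds, and the source may have more. Where it says the series, first, only, none or still open, it means among the compounds named here.

Three compounds built on the shared core of compound 1 `CC(C)(C)c1ccc(C(=O)NCc2ccc(-c3nnn[nH]3)cc2)cc1` were tested in an assay on HeLa cells with Bile acid receptor (Homo sapiens) as the target, read by a luciferase reporter, with a stated time of 24 h; on this read-out lower numbers stand for an effect already at smaller amounts and higher numbers for an effect only at larger amounts of compound. Compound 1 gives 120 nM, compound 2 `C[S+]([O-])c1ccc(CNC(=O)c2ccc(C(C)(C)C)cc2)cc1` gives 1300 nM, and compound 3 `CC(=O)Nc1ccc(CNC(=O)c2ccc(C(C)(C)C)cc2)cc1` gives 2900 nM, the highest of the three numbers. The steps were an 11-fold higher number from compound 1 to compound 2 (1.03 log units; beyond the scatter), a 24-fold higher number from compound 1 to compound 3 (1.38 log units; beyond the scatter) and a 2.2-fold higher number from compound 2 to compound 3 (0.35 log units; beyond the scatter). Compound 4 `CC(C)(C)c1ccc(C(=O)NCc2ccc(S(C)(=O)=O)cc2)cc1` differs from compound 3 by methylsulfonyl in place of acetamido on an aromatic carbon. The step that bears on it is a 2.2-fold higher number from compound 2 to compound 3 (0.35 log units; beyond the scatter), since the entering group resembles the group found in compound 2. A modest reversal of that step is therefore expected, giving a 2.2-fold lower number from compound 3 to compound 4 (0.35 log units; beyond the scatter) in this assay. For compound 4 the estimate in this assay is 1300 nM, within a range of 400 nM to 4000 nM.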

Compound 4, half-maximal effective concentration: 3800 nM
For compound 4 the middle estimate is 2.9-fold (0.47 log units) below the measured one; low and high end bracket the measured number.
By their numbers in this assay, from the lowest: compound 1; then compound 2; then compounds 3 and 4 (each within the scatter of the next).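

With a 1.3-fold higher number from compound 3 to compound 4 (0.12 log units; within the scatter) in this assay, methylsulfonyl and acetamido cannot be told apart on this aromatic carbon, para to a large group, even though one has a hydrogen-bond donor and the other has none. The sulfur-bearing group of compound 2 proved a poor guide to methylsulfonyl, with a 2.9-fold higher number from compound 2 to compound 4 (0.47 log units; beyond the scatter), while a 32-fold higher number from compound 1 to compound 4 (1.50 log units; beyond the scatter) sets 1H-tetrazol-5-yl further apart from both groups. Nothing available here explains these steps. Going by these compounds, whether a carboxylic acid or a primary amide at this place would come close to compound 1 remains open.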